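Working notes: from pyridin-4-yl to 3-fluorophenyl

A few compounds are considered here, and "the series" means these few. Any claim that something is new, unique, unknown or untested is made for them only; others in the source may bear on it.

- compound 1 `CN1CCC(C(=O)N2Cc3c(NC(=O)NCc4ccccc4)n[nH]c3C2(C)C)CC1`: 2680 nM
- compound 2 `CN1CCC(C(=O)N2Cc3c(NC(=O)c4ccc(F)c(F)c4)n[nH]c3C2(C)C)CC1`: 100 nM
- compound 3 `CN1CCC(C(=O)N2Cc3c(NC(=O)c4ccncc4)n[nH]c3C2(C)C)CC1`: 500 nM

All three values come from a functional assay on A2780 cells (Homo sapiens) for antiproliferative activity, read by fluorescence, with a stated time of 72 h; a higher number here means a weaker inhibitor, a lower number a stronger inhibitor. Compound 3 holds the middle place at 500 nM, clearly separated from both neighbours. The next change leads to compound 4 `CN1CCC(C(=O)N2Cc3c(NC(=O)c4cccc(F)c4)n[nH]c3C2(C)C)CC1` and reads 3-fluorophenyl in place of pyridin-4-yl on a carbonyl carbon.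

For the measured compounds named here, no measured compound carries 3-fluorophenyl itself, so the closest guide is compound 2, with its 3,4-difluorophenyl group. The measured step of a 5.0-fold higher number from compound 2 to compound 3 (0.70 log units; beyond the scatter) is modest and beyond the scatter, and read in reverse it points toward a lower number for compound 4. The steps of a 27-fold lower number from compound 1 to compound 2 (1.43 log units; beyond the scatter) and a 5.4-fold lower number from compound 1 to compound 3 (0.73 log units; beyond the scatter) show the same order among the three groups on the carbonyl carbon, but they start from benzylamino and bear on this change less directly.

A modest drop is therefore expected in this assay, with an estimated step of a 3.1-fold lower number from compound 3 to compound 4 (0.49 log units; beyond the scatter). For compound 4 the estimated value is 160 nM, with an expected range of 70 nM to 370 nM.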

Compound 4, half-maximal inhibitory concentration: 200 nM
Compound 4: the middle estimate sits 1.3-fold (0.10 log units) below what was measured; the measured number falls inside the stated range.
By their numbers in this assay, from the lowest: compounds 2 and 4 (each within the scatter of the next); then compound 3; then compound 1.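

In this assay the change to 3-fluorophenyl on the carbonyl carbon gives a 2.5-fold lower number from compound 3 to compound 4 (0.40 log units; beyond the scatter) and so shows that a carbon-only aromatic ring with a single fluoro also stands apart from pyridin-4-yl, a comparison that previously rested on 3,4-difluorophenyl alone. Hydrogen in place of fluoro on an aromatic carbon gives a 2.0-fold higher number from compound 2 to compound 4 (0.30 log units; within the scatter) and stays within the scatter, so this fluoro makes no readable difference here. The benzylamino group remains well separated with a 13-fold lower number from compound 1 to compound 4 (1.13 log units; beyond the scatter) and this gap holds with either fluorinated ring on the carbonyl carbon.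

Open, going by these compounds, is how plain phenyl, or a ring carrying methoxy or an amine, would compare with 3-fluorophenyl. Nothing available gives a cause for any of these differences.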